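A Methoxy Group Moved Around an Aromatic Ring

This account rests on a few compounds, and the source may have more. Where it says the series, first, only, none or still open, it means among the compounds named here.

Measured compounds:
- compound 1 `Cc1ccccc1NC(=O)Cn1cc(COc2ccc3c(c2)CCC3)nn1`: "not determined" (no result reported)
- compound 2 `COc1cccc(-n2cc(COc3ccc4c(c3)CCC4)nn2)c1`: 25.8%
- compound 3 `Cc1ccc([N+](=O)[O-])cc1NC(=O)Cn1cc(COc2ccc3c(c2)CCC3)nn1`: "not determined" (no result reported)

The three compounds share a common core, and differ in the group attached to one of its aromatic nitrogens. In an ADME assay on HEK293 cells (Homo sapiens) for inhibition, read by MTT assay, with a stated time of 48 h, tested at 25 uM (a lower number here means less inhibition, a higher number more inhibition at the concentration tested (going by the name of the read-out)), compound 2 gives 25.8%. Among the measured compounds shown here, compound 1 has no result in this assay, and compound 3 likewise has none, so compound 2 carries the only number in this set and there is no comparison among measured compounds to draw on.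

Compound 4 `COc1ccc(-n2cc(COc3ccc4c(c3)CCC4)nn2)cc1` is the compound still to be measured. It differs from compound 2 in one place: 4-methoxyphenyl in place of 3-methoxyphenyl on an aromatic nitrogen. The two compounds contain the same atoms, joined differently; only the methoxy group has changed its position on the phenyl ring.

For the measured compounds named here, with no measured step of this kind available, there is no basis for expecting a large shift in either direction. The change from compound 2 to compound 4 is expected to produce a step of a number 0.8 percentage points lower from compound 2 to compound 4 (within the scatter), that is, none beyond the scatter. Compound 4 is therefore estimated to give 25% in this assay, with a range from 10% to 40%.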

Compound 4, a percentage reported as inhibition, at one concentration (the size of the read-out at that concentration, not a potency): 21.1%
The estimate for compound 4 lay 3.9 percentage points above the measured number; low and high end bracket the measured number.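

Among the compounds shown here, compound 4 supplies the first measured step at this position: in this assay, replacing 3-methoxyphenyl with 4-methoxyphenyl on the aromatic nitrogen gives a step of a number 4.7 percentage points lower from compound 2 to compound 4 (within the scatter). Since the two compounds contain the same atoms, this pair isolates the placement of the methoxy group on the phenyl ring, and the step does not separate the two placements in this read-out. This holds for this one pair and this single tested concentration, and no measurement shown accounts for the result.

Both numbers come from compounds with a methoxy-bearing phenyl ring on this nitrogen, so the compounds shown leave open whether a different group on that ring, such as an amine or a carboxylic acid, or a longer chain in place of methoxy, such as ethoxy, would give a step beyond the scatter. They also leave open how the third placement available on the phenyl ring, 2-methoxyphenyl, would compare with compound 2 and compound 4.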